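Bromo in place of methoxy on a shared core

The compounds below may be only part of what the source reports. "The series", "measured", "known", "first", "only" and "open" are said of these compounds alone.

Compound 3 `COc1ccc(-c2cn(C[C@H]3c4c(ccc(OS(=O)(=O)c5ccc(C)cc5)c4C)[C@@H]4CC[C@@]5(C)C[C@]43CC5=O)nn2)cc1` carries a 4-methoxyphenyl group. In a functional assay on MCF7 cells (Homo sapiens) for cytotoxicity, read by MTT assay, with a stated time of 4 days (on this read-out higher numbers stand for weaker inhibition and lower numbers for stronger inhibition), compound 3 gives only a limit, > 20000 nM, not a number. Compound 1 `Cc1ccc(S(=O)(=O)Oc2ccc3c(c2C)[C@H](Cn2cc(-c4ccc(Cl)cc4)nn2)[C@@]24CC(=O)[C@@](C)(CC[C@@H]32)C4)cc1` likewise gives only the limit > 20000 nM in this assay. Compound 2 `Cc1ccc(S(=O)(=O)Oc2ccc3c(c2C)[C@H](Cn2cc(-c4ccccn4)nn2)[C@@]24CC(=O)[C@@](C)(CC[C@@H]32)C4)cc1` also gives only the limit > 20000 nM in this assay. Because of the limit of > 20000 nM in this assay, at which 3 of the 3 values shown sit, none of the steps can be read: a step that the two limits leave unreadable from compound 1 to compound 2, a step that the two limits leave unreadable from compound 1 to compound 3 and a step that the two limits leave unreadable from compound 2 to compound 3 all stay unreadable in size. Compound 4 `Cc1ccc(S(=O)(=O)Oc2ccc3c(c2C)[C@H](Cn2cc(-c4ccc(Br)cc4)nn2)[C@@]24CC(=O)[C@@](C)(CC[C@@H]32)C4)cc1` differs from compound 3 by bromo in place of methoxy on an aromatic carbon. Within the data shown here, no measured step gives a readable size for this change. Compound 1, which carries chloro, also gives only a limit in this assay. The step that the limit leaves unreadable from compound 3 to compound 4 is therefore expected to be none beyond the scatter, with another limit the most likely outcome. Compound 4 is estimated at 40000 nM, with a range from 12000 nM to 150000 nM.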

Compound 4, half-maximal inhibitory concentration: > 20000 nM
Compound 4 ended at the assay's limit; the forecaster's own chance of this, stated with the estimate: 90%; the middle value lies beyond the limit too.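

Compound 4, like compounds 1, 2 and 3, gives only a limit in this assay, so no step among these compounds can be read in size. The compounds shown leave open whether exchanging these groups on the shared core changes cytotoxicity at all.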